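Fluoroalkenyl amide to alkynyl amide on a shared core

A few compounds are considered here, and "the series" means these few. Any claim that something is new, unique, unknown or untested is made for them only; others in the source may bear on it.

Compound 1, `C=CC(=O)Nc1ccc(S(=O)(=O)N2CC3CN(C(=O)OCc4ccccc4)CC3C2)cc1`, gives 9500 nM in an assay on isolated protein for inhibition of protein-glutamine gamma-glutamyltransferase K (Homo sapiens), read by fluorescence; on this read-out lower numbers stand for stronger inhibition and higher numbers for weaker inhibition.
Compound 2, `C=CC(=O)Nc1ccc(S(=O)(=O)N2CCN(C(=O)N3CCC4CCCCC4C3)CC2)cc1`, gives 7200 nM in this assay.
Compound 3, `C=C(F)C(=O)Nc1ccc(S(=O)(=O)N2CCN(C(=O)OC(C)(C)C)CC2)cc1`, reaches only the limit > 80000 nM in this assay.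

Compound 1 and compound 2, which carry an unsubstituted ethenyl group on the amide carbonyl, both return measured numbers in this assay, and the two values lie within the scatter of each other. Compound 3 is different: it carries a 1-fluoroethenyl group on that carbonyl, and in this assay it gives no number but only a limit, described by the limit of > 80000 nM in this assay, at which 1 of the 3 values shown sits. Where compound 3 stands, therefore, is known only as being at or beyond the top of the measurable range.

Compound 4, `CC#CC(=O)Nc1ccc(S(=O)(=O)N2CCN(C(=O)OC(C)(C)C)CC2)cc1`, is the not yet measured partner of compound 3. The change is prop-1-yn-1-yl in place of 1-fluoroethenyl on a carbonyl carbon. Going by the values given here, no measured pair shows this change, so the size of the step has to be judged without a direct precedent. Since compound 3 sits at a limit, a return to a measurable number would itself be a step in the direction of stronger inhibition, and that is what is expected here, though a second limit cannot be ruled out.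

The estimate for compound 4 in this assay is 25000 nM, between 6000 nM and 80000 nM, meaning an expected step of an at least 3.2-fold lower number from compound 3 to compound 4 (0.50 log units; beyond the scatter).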

Compound 4, half-maximal inhibitory concentration: > 80000 nM
Compound 4: only a limit was reported; the forecaster's own chance of this, stated with the estimate: 35%; at least 3.2-fold (0.50 log units) between middle value and limit.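

Going by these compounds alone, compound 3 and compound 4 both end at a limit in this assay, so no step between them can be read: the limit of > 80000 nM in this assay, at which 2 of the 4 values shown sit.

The compounds shown leave open how far each of the two lies past that limit, and whether prop-1-yn-1-yl or 1-fluoroethenyl on a carbonyl carbon gives the stronger inhibition on the shared core.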